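Compound 1 to compound 3: losing the cyclopentyl group

This account rests on a few compounds, and the source may have more. Where it says the series, first, only, none or still open, it means among the compounds named here.

Within the data shown here, in a functional assay on MCF7 cells (Homo sapiens) for antiproliferative activity, read by MTT assay, with a stated time of 24 h (on this read-out higher numbers stand for weaker inhibition and lower numbers for stronger inhibition), compound 1 (`COc1ccc(-c2noc(-c3ccc(F)cc3)n2)cc1OC1CCCC1`) gives 3880 nM as the only exact number so far. In this assay compound 2 (`COc1ccc(-c2noc(-c3cccnc3)n2)cc1OC1CCCC1`) stands at > 1000000 nM as a limit of the assay and not a number.

Compound 3 (`COc1ccc(-c2noc(-c3ccc(F)cc3)n2)cc1O`) departs from compound 1 by hydrogen in place of cyclopentyl on an oxygen on an aromatic ring in a change that reads cyclopentyloxy to hydroxy.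

Among the measured compounds shown here, the only measured step is large and lies at another place on the core: an at least 250-fold higher number from compound 1 to compound 2 (2.41 log units; beyond the scatter) with pyridin-3-yl in place of 4-fluorophenyl. For the measured compounds named here, no step at the cyclopentyl place has been measured, so this step bears on the change only indirectly. It shows that one change can cost a great deal in this pair. Going by the values given here, with compound 2 and its an at least 250-fold higher number from compound 1 to compound 2 (2.41 log units; beyond the scatter) as the sole guide, a shift towards a higher number in this assay is expected, though a smaller one and with wide uncertainty. The expected change is a 3.1-fold higher number from compound 1 to compound 3 (0.49 log units; beyond the scatter) in this estimate. For compound 3 the estimated value is 12000 nM with an expected range from 2500 nM to 60000 nM in this assay.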

Compound 3, half-maximal inhibitory concentration: > 1000000 nM
Compound 3: a limit, no number; the forecaster's own chance of this, stated with the estimate: 12%; at least 83-fold (1.92 log units) between middle value and limit.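

In this assay the cyclopentyl place now has a measured step of its own, and it is large: an at least 250-fold higher number from compound 1 to compound 3 (2.41 log units; beyond the scatter). Compound 3 stands at > 1000000 nM, which is a limit of the assay and not a number. The exact value of compound 1 therefore does not survive cutting cyclopentyloxy back to hydroxy, so this oxygen substituent matters as much as the 4-fluorophenyl place, and the size of the step is only a lower bound set by where the read-out stops: the limit of > 1000000 nM in this assay, at which 2 of the 3 values shown sit.

The compounds shown span only cyclopentyl and hydrogen on this oxygen, so it remains open whether a smaller ether such as methoxy, a longer chain such as n-butyl, or a chain ending in an amine would bring back a measurable number. Among these compounds, with compound 1 as the only exact value so far, it is also open how far beyond the limit each of the two changes reaches.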